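A fluorinated aromatic group joins a closely matched trio

The source may report more compounds than this note shows. Statements on the series, on what has been measured and on what is new or still open speak of the compounds shown alone.

In a functional assay on HT-29 cells (Homo sapiens) for antiproliferative activity, read by MTT assay, with a stated time of 72 h (a higher number here means a weaker inhibitor, a lower number a stronger inhibitor), compound 1 `Cc1ccccc1N1CCN(C(=S)SCc2ccc3nc(N)nc(N)c3c2)CC1` gives 2950 nM, compound 2 `Nc1nc(N)c2cc(CSC(=S)N3CCN(c4ccccc4Cl)CC3)ccc2n1` gives 3900 nM and compound 3 `Nc1nc(N)c2cc(CSC(=S)N3CCN(c4ccc(Cl)c(Cl)c4)CC3)ccc2n1` gives 3480 nM. Compound 3 therefore lies within the scatter of both others, and the numbers do not separate the three.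

Compound 4 `Nc1nc(N)c2cc(CSC(=S)N3CCN(c4ccc(F)cc4)CC3)ccc2n1` keeps the shared core but carries 4-fluorophenyl in place of 3,4-dichlorophenyl on an amine nitrogen in a ring. Three measured steps change the group at this same place: a 1.3-fold higher number from compound 1 to compound 2 (0.12 log units; within the scatter), a 1.2-fold higher number from compound 1 to compound 3 (0.07 log units; within the scatter) and a 1.1-fold lower number from compound 2 to compound 3 (0.05 log units; within the scatter). All are small, though none tests fluorine. The step expected in this assay is therefore none beyond the scatter, an estimated 1.0-fold lower number from compound 3 to compound 4 (0.01 log units; within the scatter). Compound 4 is expected at 3400 nM, with an estimated range of 1700 nM to 6800 nM.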

Compound 4, half-maximal inhibitory concentration: 2050 nM
For compound 4 the middle estimate is 1.7-fold (0.22 log units) above the measured one, and the stated range covers the measured number.
By their numbers in this assay, from the lowest: compounds 4, 1, 3 and 2 (each within the scatter of the next).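

In this assay the 4-fluorophenyl group, the only fluorinated one shown, cannot be told apart from the other aromatic groups on this amine nitrogen: the steps are a 1.7-fold lower number from compound 3 to compound 4 (0.23 log units; within the scatter), a 1.9-fold lower number from compound 2 to compound 4 (0.28 log units; within the scatter) and a 1.4-fold lower number from compound 1 to compound 4 (0.16 log units; within the scatter). So at this place, fluorine on the phenyl ring gives no separation that this assay can resolve from chlorine or methyl. No measurement here bears on the reason for these small differences.

Every group shown at this place is a substituted phenyl ring. On these data alone, whether a pyridine ring, a plain alkyl chain or a phenyl ring carrying a carboxylic acid would separate from them stays open.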